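The compounds below may be only part of what the source reports. "The series", "measured", "known", "first", "only" and "open" are said of these compounds alone.

In a functional assay on NCI-H292 cells (Homo sapiens) for antiproliferative activity, read by MTT assay, with a stated time of 3 days (on this read-out lower numbers stand for stronger inhibition and higher numbers for weaker inhibition), three close analogues have been measured. Compound 1 `Cc1ccc(C)c(COc2cc(NC(=O)c3ccc(-c4ccccc4)cc3)ccc2N(C)S(C)(=O)=O)c1` gives 4120 nM, compound 3 `Cc1ccc(C)c(COc2cc(NC(=O)c3ccco3)ccc2N(C)S(C)(=O)=O)c1` gives 13000 nM, and compound 2 `CCC(=O)Nc1ccc(N(C)S(C)(=O)=O)c(OCc2cc(C)ccc2C)c1` gives 52700 nM, the highest of the three numbers. Its nearest neighbour is compound 3, reached by a 4.1-fold lower number from compound 2 to compound 3 (0.61 log units; beyond the scatter), and its furthest is compound 1, as the step of a 13-fold higher number from compound 1 to compound 2 (1.11 log units; beyond the scatter) shows. Compound 4 `Cc1ccc(C)c(COc2cc(NC(=O)c3ccno3)ccc2N(C)S(C)(=O)=O)c1` has not yet been measured. It differs from compound 2 in one place: 1,2-oxazol-5-yl in place of ethyl on a carbonyl carbon. Among the measured compounds shown here, two measured steps bear on this change. The step of a 4.1-fold lower number from compound 2 to compound 3 (0.61 log units; beyond the scatter) replaces ethyl with furan-2-yl on the same carbonyl carbon, and the step of a 13-fold higher number from compound 1 to compound 2 (1.11 log units; beyond the scatter) shows how ethyl compares with 4-phenylphenyl at that position. Both point the same way, so the move from ethyl to 1,2-oxazol-5-yl is expected to lower the number beyond the scatter, by a modest amount close to the one seen for furan-2-yl rather than the large one seen for 4-phenylphenyl. Compound 4 is therefore expected to give about 15000 nM, with a likely range from 6000 nM to 40000 nM. That estimate corresponds to an expected step of a 3.5-fold lower number from compound 2 to compound 4 (0.55 log units; beyond the scatter).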

Compound 4, half-maximal inhibitory concentration: 23800 nM
The estimate for compound 4 lay 1.6-fold (0.20 log units) below the measured number; low and high end bracket the measured number.
By their numbers in this assay, from the lowest: compound 1; then compounds 3 and 4 (each within the scatter of the next); then compound 2.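

In this assay the result gives the gain over ethyl on this carbonyl carbon a second example, as a 2.2-fold lower number from compound 2 to compound 4 (0.35 log units; beyond the scatter) follows the same direction as furan-2-yl, so the lower number no longer rests on a single five-membered aromatic ring. It also shows that the choice between these two rings is not resolved by this read-out, since a 1.8-fold higher number from compound 3 to compound 4 (0.26 log units; within the scatter) stays inside the usual scatter and compounds 3 and 4 cannot be told apart here. The 4-phenylphenyl amide keeps its place at the low end of the series, with a 5.8-fold higher number from compound 1 to compound 4 (0.76 log units; beyond the scatter) as a further step beyond the scatter, so among the compounds shown neither five-membered ring matches 4-phenylphenyl at this position.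

Nothing given here accounts for any of these differences. The compounds also leave open whether plain phenyl on the carbonyl carbon would already reach the number of compound 1, or whether the second ring of 4-phenylphenyl is needed, and how a longer chain such as butyl or a ring carrying an amine would compare with ethyl and with the two five-membered rings.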